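A few compounds are considered here, and "the series" means these few. Any claim that something is new, unique, unknown or untested is made for them only; others in the source may bear on it.

Among the measured compounds shown here, in an ADME assay on MDBK cells (Bos taurus) for cytotoxicity, read by MTT assay, with a stated time of 96 h (a lower number here means that less compound is tolerated, a higher number that more compound is tolerated), no tested compound has yet given a number. Compound 1 (`COc1ccc(-c2nc3cc(C(F)(F)F)ccc3[nH]2)c(OC)c1`) reads > 100000 nM here, which is a limit of the assay. Compound 2 (`COc1ccc(-c2nc3cc(C(F)(F)F)ccc3[nH]2)c(OC)c1OC`) gives > 100000 nM as a limit too. Compound 3 (`COc1ccc(-c2nc3cc([N+](=O)[O-])ccc3[nH]2)c(OC)c1`) also gives > 100000 nM as a limit, and that is all that can be said of where it stands. The whole picture so far is the limit of > 100000 nM in this assay, at which 3 of the 3 values shown sit, and nothing finer.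

Compound 4 (`COc1ccc(-c2nc3cc([N+](=O)[O-])ccc3[nH]2)c(OC)c1OC`) differs from compound 3 by one change (methoxy in place of hydrogen on an aromatic carbon), a methoxy in place of hydrogen on an aromatic carbon. The same swap has been made once before (a step that the two limits leave unreadable from compound 1 to compound 2) and offers the closest guide. The exchange of trifluoromethyl for nitro (a step that the two limits leave unreadable from compound 1 to compound 3) bears on it less directly. Neither step has a readable size, so no step beyond the scatter is expected in this assay in either direction. Compound 4 is estimated at 100000 nM with an expected range from 50000 nM to 100000 nM and a good chance of another limit. That estimate implies the expected step (a number no higher from compound 3 to compound 4 (the limit leaves the size open)) and nothing larger.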

Compound 4, half-maximal cytotoxic concentration: > 100000 nM
Compound 4: only a limit was reported (the forecaster's own chance of this, stated with the estimate: 85%); the middle value sits exactly at the limit.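

The steps to compound 4 from compound 3 and from compound 2 cannot be read; each pair gives only limits, not numbers. The compounds shown leave open at what concentration any of them would harm the cells, and whether the methoxy or the nitro swap alters that concentration: the limit of > 100000 nM in this assay, at which 4 of the 4 values shown sit.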